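A few compounds are considered here, and "the series" means these few. Any claim that something is new, unique, unknown or untested is made for them only; others in the source may bear on it.

Of the compounds shown here, three have so far been measured in a physicochemical assay for lipophilicity, using the shake flask method, in phosphate buffer, measured as octanol-water partition, at pH 7.4; a lower number here means a more polar compound, a higher number a more lipophilic compound. Compound 2 `CC[C@H](c1ccc(C(=O)O)c(Oc2cccc(Cl)c2)c1)N1CCC[C@H](n2cc(C)c(=O)[nH]c2=O)C1` gives 0.22. Compound 3 `CC[C@@H](c1ccc(C(=O)O)c(Oc2cccc(Cl)c2)c1)N1CCC[C@H](n2cc(C)c(=O)[nH]c2=O)C1` differs from compound 2 in one respect only: the two compounds have the same atoms and bonds and differ only in configuration as drawn: 1 of 2 stereo elements differ; a stereocentre at a saturated chain carbon is drawn R in compound 2 and S in compound 3. In this assay compound 3 gives 0.22, and the step is no change at the digits printed from compound 2 to compound 3 (within the scatter), which fits with the fact that compounds 2 and 3 differ only in the configuration as drawn. Compound 1 `CC[C@H](c1ccc(C(=O)O)c(Oc2cccc(Cl)c2)c1OC)N1CCC[C@H](n2cc(C)c(=O)[nH]c2=O)C1` carries a change relative to compound 2, (methoxy in place of hydrogen on an aromatic carbon). In this assay compound 1 gives -0.13, a step of a number 0.35 log units lower from compound 2 to compound 1 (beyond the scatter). Compound 4 `CC[C@@H](c1ccc(C(=O)O)c(Oc2cccc(Cl)c2)c1OC)N1CCC[C@H](n2cc(C)c(=O)[nH]c2=O)C1` has not yet been measured. It carries the same change relative to compound 3, at the same place: methoxy in place of hydrogen on an aromatic carbon. Resting on the measured step of a number 0.35 log units lower from compound 2 to compound 1 (beyond the scatter), the step from compound 3 to compound 4 is expected to be a number 0.35 log units lower from compound 3 to compound 4 (beyond the scatter). Compound 4 is therefore estimated at -0.13, with a likely range from -0.4 to 0.15.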

Compound 4, distribution coefficient: -0.02
Estimate against measurement, compound 4: 0.11 log units below; the measured number falls inside the stated range.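

In this assay, methoxy in place of hydrogen on an aromatic carbon gives a number 0.24 log units lower from compound 3 to compound 4 (within the scatter), against a number 0.35 log units lower from compound 2 to compound 1 (beyond the scatter), so a step beyond the scatter on one pair is not repeated beyond the scatter on the other. The remaining new step, a number 0.11 log units higher from compound 1 to compound 4 (within the scatter), fits with one plain fact: the fact that compounds 1 and 4 differ only in the configuration as drawn. The two cores here have the same atoms and bonds, so this shows how the change carries across a difference in configuration, not to a core with different atoms.

Still open, from the compounds shown here alone, is how an ethoxy group or an amine at that same place would read in this assay. Also open, going by these compounds, is whether the methoxy step would reach the same size on a core with different atoms.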